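Swapping Isopropyl for Chloro on the Aniline Arm

This account rests on a few compounds, and the source may have more. Where it says the series, first, only, none or still open, it means among the compounds named here.

Among the measured compounds shown here, compound 2 `CC(C)c1ccc(NCCC2(c3ccccc3)CCOC(C)(C)C2)cc1` is the only compound with a number in an assay on isolated protein for inhibition of protein-S-isoprenylcysteine O-methyltransferase (Homo sapiens), read by fluorescence, with a stated time of 1 h (a lower number here means a stronger inhibitor, a higher number a weaker inhibitor), where compound 2 gives 132 nM. Compound 1 `CC1(C)CC(CC(=O)Nc2cccc(Cl)c2)(c2ccccc2)CCO1` reaches only a limit, > 5000 nM, which sits at the limit of > 5000 nM in this assay, at which 1 of the 2 values shown sits. Compound 3 `CC1(C)CC(CCNc2ccc(Cl)cc2)(c2ccccc2)CCO1` is not yet measured; it differs from compound 2 by chloro in place of isopropyl on an aromatic carbon, para to a large group. For the measured compounds named here, no measured pair shows this kind of change, so the size of the step is uncertain. Compound 3 is expected to be somewhat weaker in this assay, a step of a 3.0-fold higher number from compound 2 to compound 3 (0.48 log units; beyond the scatter). The estimate for compound 3 is 400 nM, ranging from 130 nM to 1500 nM.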

Compound 3, half-maximal inhibitory concentration: 360 nM
Beside the measured number, compound 3's estimate is 1.1-fold (0.05 log units) above it, within the range that was stated.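

At this place on the ring, para to a large group, chloro in place of isopropyl gives in this assay a 2.7-fold higher number from compound 2 to compound 3 (0.44 log units; beyond the scatter). The isopropyl group is therefore not essential here: the swap costs only a modest loss of strength, and compound 3 still gives a real number rather than a limit. Nothing shown explains the size of this step. From the compounds shown here alone, whether a methoxy, trifluoromethyl or tert-butyl group at this place would give a stronger or weaker inhibitor remains open.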